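Swapping the thiazole for a nitrile on the amide nitrogen

A few compounds are considered here, and "the series" means these few. Any claim that something is new, unique, unknown or untested is made for them only; others in the source may bear on it.

Of the compounds shown here, two have been measured in an assay on HEK293 cells for displacement of a labelled ligand from Type-2 angiotensin II receptor (Homo sapiens), tested at 1 uM; a lower number here means a weaker effect, a higher number a stronger effect of the compound at the concentration tested. Compound 1 `CC[C@H](C)[C@H](NC(=O)c1cccc(Cn2ccnc2)c1)C(=O)NNS(=O)(=O)c1c(C)cc(C)cc1C` gives 10%. Compound 2 `CC[C@H](C)[C@H](NC(=O)c1cccc(Cn2ccnc2)c1)C(=O)Nc1nccs1` gives 4%, the lower of the two numbers, though its distance from compound 1 lies within the usual scatter. Compound 3 `CC[C@H](C)[C@H](NC(=O)c1cccc(Cn2ccnc2)c1)C(=O)NC#N` has not yet been measured. It differs from compound 2 in one place: cyano in place of 1,3-thiazol-2-yl on an amide-type nitrogen. For the measured compounds named here, with no step between measured compounds to lean on, the expected step from compound 2 to compound 3 in this assay is none beyond the scatter, a number 1 percentage points higher from compound 2 to compound 3 (within the scatter). Compound 3 is therefore expected to give about 5%, with a range from 0% to 15%.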

Compound 3, a percentage reported as inhibition, at one concentration (the size of the read-out at that concentration, not a potency): 6%
Estimate against measurement, compound 3: 1 percentage points below, and the stated range covers the measured number.
By their numbers in this assay, from the lowest: compounds 2, 3 and 1 (each within the scatter of the next).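

In this assay, cyano in place of 1,3-thiazol-2-yl on an amide-type nitrogen gives a number 2 percentage points higher from compound 2 to compound 3 (within the scatter). Removing the ring and leaving a much smaller group at this position therefore causes no change that this read-out can separate from the scatter. No measurement is available to explain this result. On these data alone, it remains open whether any group on this nitrogen can raise the read-out beyond the scatter. A carboxylic acid, an amine or a longer chain such as n-butyl would each put that question to the test.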